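Putting a carbonyl group back on compound 3

The compounds below may be only part of what the source reports. "The series", "measured", "known", "first", "only" and "open" are said of these compounds alone.

In an in vitro ADME assay on microsomes from liver (Homo sapiens) for metabolic stability, tested at 1 uM (on this read-out lower numbers stand for a shorter-lived compound and higher numbers for a longer-lived compound), compound 1 (`O=C(c1cccnc1)N1CCC(NS(=O)(=O)c2cc(S(=O)(=O)c3ccccc3)ccc2C(F)(F)F)CC1`) gives 0.1 h as its measured value. Compound 2 (`CN(C)c1ccc(C(=O)N2CCC(NS(=O)(=O)c3cc(S(=O)(=O)c4ccccc4)ccc3C(F)(F)F)CC2)cn1`) gives 0.05 h on the same read-out, and the step between these two stays within the scatter (a 2.0-fold lower number from compound 1 to compound 2 (0.30 log units; within the scatter)). Compound 3 (`CC(C)(O)CCN1CCC(NS(=O)(=O)c2cc(S(=O)(=O)c3ccccc3)ccc2C(F)(F)F)CC1`) gives < 0.0167 h as a limit of the assay, not a number. Compound 4 (`O=C(C1CCNCC1)N1CCC(NS(=O)(=O)c2cc(S(=O)(=O)c3ccccc3)ccc2C(F)(F)F)CC1`) differs from compound 3 by one change ((piperidin-4-yl)carbonyl in place of 3-hydroxy-3-methylbutyl on an amine nitrogen in a ring), with (piperidin-4-yl)carbonyl in place of 3-hydroxy-3-methylbutyl on an amine nitrogen in a ring. A carbonyl group also sits on that nitrogen in the two other measured compounds, and the steps away from it lie beyond the scatter (an at least 5.9-fold lower number from compound 1 to compound 3 (0.77 log units; beyond the scatter); an at least 2.9-fold lower number from compound 2 to compound 3 (0.47 log units; beyond the scatter)). Read in reverse, they make a rise the expected direction here (an at least 2.9-fold higher number from compound 3 to compound 4 (0.47 log units; beyond the scatter)). For compound 4 the expected half-life is 0.05 h (estimated range 0.02 h to 0.15 h).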

Compound 4, half-life: > 0.5 h
Compound 4 gave a limit, no number; the forecaster's own chance of this, stated with the estimate: 15%; middle value at least 10-fold (1.00 log units) away from the limit.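

On the amine nitrogen in a ring, a carbonyl alone does not settle the half-life in this assay: what that carbonyl carries also counts, as piperidin-4-yl outlasts 6-(dimethylamino)pyridin-3-yl, an at least 10-fold higher number from compound 2 to compound 4 (1.00 log units; beyond the scatter), and pyridin-3-yl, an at least 5.0-fold higher number from compound 1 to compound 4 (0.69 log units; beyond the scatter). The change from 3-hydroxy-3-methylbutyl gives a large step, an at least 29-fold higher number from compound 3 to compound 4 (1.47 log units; beyond the scatter). Compound 4 stands at a limit of the assay, and these steps are minimum sizes: the limit of > 0.5 h in this assay, at which 1 of the 4 values shown sits.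

The compounds shown do not separate the nitrogen of piperidin-4-yl from its non-aromatic ring. A cyclohexyl group on the same carbonyl would test that.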